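Aryl to methyl swap on the shared core

This account rests on a few compounds, and the source may have more. Where it says the series, first, only, none or still open, it means among the compounds named here.

compound 1 `Cc1nc2c3ccccc3ccc2c2nc3c(ccc4ccccc43)c(-c3ccccc3Cl)c12`: 118 ug/mL
compound 2 `Cc1nc2c3ccccc3ccc2c2nc3c(ccc4ccccc43)c(-c3ccc(O)cc3)c12`: 86.4 ug/mL

In a functional assay, read by spectrophotometry, with a stated time of 30 min (on this read-out higher numbers stand for weaker inhibition and lower numbers for stronger inhibition), compound 1 gives 118 ug/mL, and compound 2 gives 86.4 ug/mL. Among the compounds with values here, compound 2 stands alongside compound 1: the single measured step, a 1.4-fold lower number from compound 1 to compound 2 (0.14 log units; within the scatter), is within the scatter, so the two are not separated. Compound 3 `Cc1nc2c3ccccc3ccc2c2nc3c(ccc4ccccc43)c(C)c12` differs from compound 2 by methyl in place of 4-hydroxyphenyl on an aromatic carbon. Within the data shown here, no measured step covers this change; the step of a 1.4-fold lower number from compound 1 to compound 2 (0.14 log units; within the scatter) exchanges one aryl for another and was within the scatter. Accordingly no shift beyond the scatter is expected for compound 3 in this assay. Compound 3 is estimated at 105 ug/mL, range 50 ug/mL to 220 ug/mL, an expected step of a 1.2-fold higher number from compound 2 to compound 3 (0.08 log units; within the scatter).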

Compound 3, half-maximal inhibitory concentration: 129 ug/mL
Beside the measured number, compound 3's estimate is 1.2-fold (0.09 log units) below it, within the range that was stated.
By their numbers in this assay, from the lowest: compounds 2, 1 and 3 (each within the scatter of the next).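

In this assay, methyl in place of an aryl group at this position gives a 1.5-fold higher number from compound 2 to compound 3 (0.17 log units; within the scatter) and a 1.1-fold higher number from compound 1 to compound 3 (0.04 log units; within the scatter). The ring carried here is therefore not required for a number at this level: neither 4-hydroxyphenyl nor 2-chlorophenyl is separated from methyl on the shared core. No supporting data bear on the reason for this result.

As far as these compounds go, whether an amine, a carboxylic acid or a longer chain at this position would move the number beyond the scatter remains open. From the compounds shown here alone, the effect of changes elsewhere on the shared core also remains open.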